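Working notes: the step from compound 3 to compound 4

A few compounds are considered here, and "the series" means these few. Any claim that something is new, unique, unknown or untested is made for them only; others in the source may bear on it.

compound 1 `COC1=C(C)C(=O)/C(=C(O)/C=C/c2ccccc2OC)C(=O)C1(C)C`: 3.3 ug/mL
compound 2 `CCc1ccc(/C=C/C(O)=C2/C(=O)C(C)=C(OC)C(C)(C)C2=O)cc1`: 6.9 ug/mL
compound 3 `C=Cc1ccccc1/C=C/C(O)=C1/C(=O)C(C)=C(OC)C(C)(C)C1=O`: 1.9 ug/mL

In a functional assay on KB cells (Homo sapiens) for cytotoxicity (a lower number here means that less compound is needed, a higher number that more compound is needed for the effect), compound 3 gives 1.9 ug/mL. The nearer of its two gaps is a 1.7-fold lower number from compound 1 to compound 3 (0.24 log units; within the scatter), which stays inside the scatter. The wider gap is a 3.6-fold lower number from compound 2 to compound 3 (0.56 log units; beyond the scatter), which goes beyond it.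

The next member is compound 4 `COC1=C(C)C(=O)/C(=C(O)/C=C/c2nccs2)C(=O)C1(C)C`. It carries 1,3-thiazol-2-yl in place of 2-vinylphenyl on a double-bonded chain carbon bound to a double-bonded chain carbon. Among the compounds with values here, no measured compound has a five-membered aromatic ring with 2 hetero atoms at that place, so the change has no direct precedent.

The closest evidence is the set of changes to the aromatic group at that same place. Besides the two gaps above, there is a 2.1-fold higher number from compound 1 to compound 2 (0.32 log units; beyond the scatter). These steps are modest at most, and all three values lie close together. A step of similar modest size is therefore expected, with the direction uncertain but more likely toward a higher number, as compound 3 has no measured value beneath it beyond the scatter.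

The expected step is a 2.4-fold higher number from compound 3 to compound 4 (0.37 log units; beyond the scatter). For compound 4 the estimated value is 4.5 ug/mL, with an expected range from 1.5 ug/mL to 13 ug/mL.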

Compound 4, concentration for half-maximal effect: 4.3 ug/mL
Compound 4: the middle estimate sits 1.0-fold (0.02 log units) above what was measured; the measured number falls inside the stated range.
By their numbers in this assay, from the lowest: compounds 3, 1, 4 and 2 (each within the scatter of the next, the first and the last beyond it).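

In this assay this place, on a double-bonded chain carbon bound to a double-bonded chain carbon, accepts 1,3-thiazol-2-yl, a five-membered aromatic ring with 2 hetero atoms, with no separation from two of the compounds carrying a six-membered aromatic ring of carbon only: a 1.6-fold lower number from compound 2 to compound 4 (0.21 log units; within the scatter) and a 1.3-fold higher number from compound 1 to compound 4 (0.11 log units; within the scatter) both remain within the scatter. Within the data shown here, compound 3 is the exception among those compounds, with a 2.3-fold higher number from compound 3 to compound 4 (0.35 log units; beyond the scatter) as a modest step beyond the scatter, so a six-membered aromatic ring of carbon only is not needed for values in this range, although 2-vinylphenyl is the one group here that separates from 1,3-thiazol-2-yl. No measurement on hand explains any of these steps.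

With a single heteroaromatic group in the set, the compounds shown cannot separate the contribution of the ring nitrogen from that of the ring sulfur, and thiophen-2-yl, pyridin-2-yl or furan-2-yl at the same place would bear on that question. From the compounds shown here alone, it also remains open whether the 1,3-thiazol-2-yl ring would tolerate an added methyl, an amine or a carboxylic acid, or whether a vinyl group on it would reach the value of compound 3 at 1.9 ug/mL in this assay.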